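Replacing the Indole in a Thioether Enone Series

The source may report more compounds than this note shows. Statements on the series, on what has been measured and on what is new or still open speak of the compounds shown alone.

compound 1 `O=C(O)c1ccc(C(=O)/C(=C\c2ccc(Br)c([N+](=O)[O-])c2)SCc2ccccc2Cl)cc1`: 1000 nM in a functional assay on DU-145 cells (Homo sapiens) for inhibition, read by trypan blue exclusion, with a stated time of 96 h; on this read-out lower numbers stand for stronger inhibition of growth and higher numbers for weaker inhibition of growth
compound 2 `Cc1ccc(S/C(=C/c2c[nH]c3ccccc23)C(=O)c2ccc(Br)cc2)cc1`: 10000 nM in this assay

Of the two measured compounds, compound 2 stands at the higher number, and compound 1 at the lower one, a gap beyond the usual scatter. The two differ in several places at once, so the values alone say nothing about which change matters.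

Compound 3 `Cc1ccc(S/C(=C/c2ccc(Cl)c(Cl)c2)C(=O)c2ccc(Br)cc2)cc1` differs from compound 2 in a single place: 3,4-dichlorophenyl in place of 1H-indol-3-yl on a double-bonded chain carbon bound to a double-bonded chain carbon. For the measured compounds named here, no measured pair shows this change, so its size is unknown. Because compound 1, which carries a substituted phenyl at the same kind of position, gives 1000 nM, a modest step toward a lower number is expected, though it may stay within the scatter. The expected step is a 2.0-fold lower number from compound 2 to compound 3 (0.30 log units; within the scatter). Compound 3 is expected to give about 5000 nM, within 1500 nM to 20000 nM.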

Compound 3, concentration for 50% growth inhibition: 50000 nM
Estimate against measurement, compound 3: 10-fold (1.00 log units) below; the whole stated range lies below it.
By their numbers in this assay, from the lowest: compound 1; then compound 2; then compound 3.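

Putting 3,4-dichlorophenyl in place of 1H-indol-3-yl on a double-bonded chain carbon bound to a double-bonded chain carbon gives a 5.0-fold higher number from compound 2 to compound 3 (0.70 log units; beyond the scatter) in this assay and so weakens growth inhibition. This position therefore responds to the group it carries, and of these two groups, 1H-indol-3-yl goes with the stronger inhibition. No supporting data bear on why this change weakens inhibition.

The group that leaves has a hydrogen-bond donor and a five-membered aromatic ring, while the group that enters has neither and brings two chlorine atoms, and this single step cannot tell which of these differences matters. A plain phenyl or a naphthyl group at the same place would help separate the effect of the chlorines from that of the indole's ring system and its nitrogen.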